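Hydroxy analogue of compound 2 in the ester series

A few compounds are considered here, and "the series" means these few. Any claim that something is new, unique, unknown or untested is made for them only; others in the source may bear on it.

Compound 1 `CCOC(=O)[C@@H]1C(=O)N(Cc2ccccc2)C[C@@H](O)[C@H]1c1ccccc1` and compound 2 `CCOC(=O)[C@@H]1C(=O)N(Cc2ccccc2)C[C@@H](ON2C(C)(C)CCCC2(C)C)[C@H]1c1ccc(C)cc1` share the same core. In a physicochemical assay, with a stated time of 60 min (on this read-out lower numbers stand for stronger inhibition and higher numbers for weaker inhibition), compound 1 sits at the limit of the assay, > 100000 nM, a limit and not a number. In this assay, going by the values given here, compound 2 gives 98400 nM; this is the only number in the set. The remaining entry is the limit of > 100000 nM in this assay, at which 1 of the 2 values shown sits, so compound 2 stands without a ranked neighbour. Compound 3 `CCOC(=O)[C@@H]1C(=O)N(Cc2ccccc2)C[C@@H](O)[C@H]1c1ccc(C)cc1` has not been measured. Compound 3 differs from compound 2 by hydrogen in place of 2,2,6,6-tetramethylpiperidin-1-yl on an oxygen on a saturated carbon. Among the compounds with values here, no measured pair tracks this change. The expected step from compound 2 to compound 3 in this assay is a 1.1-fold lower number from compound 2 to compound 3 (0.04 log units; within the scatter), none beyond the usual scatter. Compound 3 is expected to give 90000 nM in this assay, within 40000 nM to 200000 nM, with a real chance that only a limit is returned.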

Compound 3, half-maximal inhibitory concentration: > 100000 nM
Compound 3: a limit, no number; the forecaster's own chance of this, stated with the estimate: 55%; middle value at least 1.1-fold (0.04 log units) from the limit.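

Going from (2,2,6,6-tetramethylpiperidin-1-yl)oxy to hydroxy at this position gives, in this assay, an at least 1.0-fold higher number from compound 2 to compound 3 (0.00 log units; that floor lies within the scatter), so the change has a readable floor but no readable size. The hydroxy group on the 4-methylphenyl-free and methyl-bearing compounds alike now yields no number, and compound 1 and compound 3 both rest on a limit of the assay: the limit of > 100000 nM in this assay, at which 2 of the 3 values shown sit.

The step from compound 1 to compound 3 cannot be read, as a pair of limits gives no size for methyl in place of hydrogen on an aromatic carbon.

From the compounds shown here alone, whether a smaller group on this oxygen, such as a methyl or benzyl ether, would return a number remains open. So does whether an amine or a carboxylic acid on the shared core would bring values clearly under the limit.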